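Swapping an Aryl Group for an Acetylpiperidine

The source may report more compounds than this note shows. Statements on the series, on what has been measured and on what is new or still open speak of the compounds shown alone.

Measured in a functional assay on HT-29 cells (Homo sapiens) for cytotoxicity, read by resazurin assay, with a stated time of 48 h; a higher number here means that more compound is needed for the effect, a lower number that less compound is needed:
- compound 1 `COc1ccc(S(=O)(=O)Nc2ccc3oc(-c4ccc(NC(=O)c5cccc(C)c5[N+](=O)[O-])cc4)nc3c2)cc1`: 2300 nM
- compound 2 `O=S(=O)(Nc1ccc(-c2nc3cc(NS(=O)(=O)c4ccc(Br)cc4)ccc3o2)cc1)c1ccc(Br)cc1`: 17000 nM
- compound 3 `O=C(Nc1ccc(Sc2nc3ccccc3s2)cc1)c1cccc(Br)c1O`: 9300 nM

Compound 1 has the lowest number of the three, so it needs the least compound for the effect. Compound 2 and compound 3 both lie above it, beyond the scatter of repeated measurements.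

Compound 4 `COc1ccc(S(=O)(=O)Nc2ccc3oc(-c4ccc(NC(=O)C5CCN(C(C)=O)CC5)cc4)nc3c2)cc1` keeps the rest of compound 1 but carries 1-acetylpiperidin-4-yl in place of 3-methyl-2-nitrophenyl on a carbonyl carbon. An aromatic ring of carbon only thus gives way to a non-aromatic ring with a hetero atom.

Within the data shown here, no pair of measured compounds differs in one place, so nothing here tests this change directly. Among the measured compounds shown here, compound 1, at 2300 nM, is the lowest of only three values, so a higher number seems the likelier outcome in this assay. A modest upward move is expected, estimated as a 2.6-fold higher number from compound 1 to compound 4 (0.42 log units; beyond the scatter). For compound 4 the expected value is 6000 nM, with an estimated range of 1800 nM to 25000 nM.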

Compound 4, half-maximal effective concentration: 16000 nM
Estimate against measurement, compound 4: 2.7-fold (0.43 log units) below; low and high end bracket the measured number.
By their numbers in this assay, from the lowest: compound 1; then compounds 3, 4 and 2 (each within the scatter of the next).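

Among these compounds, this is the first direct test of the group on the carbonyl carbon. In this assay, putting 1-acetylpiperidin-4-yl in place of 3-methyl-2-nitrophenyl gives a 7.0-fold higher number from compound 1 to compound 4 (0.84 log units; beyond the scatter) with the rest of the molecule unchanged, so this position does influence how much compound is needed, and here the aromatic ring of carbon only needs less than this non-aromatic ring with a hetero atom. No measurement shown here accounts for the shift.

A single swap cannot separate the loss of the aromatic ring from the loss of the nitro and methyl groups, or from the arrival of the acetyl group. As far as these compounds go, whether an unsubstituted phenyl ring, a piperidine without its acetyl group, or a carboxylic acid at this place would stay nearer compound 1 or compound 4 remains open.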